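This account rests on a few compounds, and the source may have more. Where it says the series, first, only, none or still open, it means among the compounds named here.

Working notes on the series. Compound 1 `O=C(N/N=C/c1cccc(Cl)c1)c1cccnc1Nc1cccc(C(F)(F)F)c1` and compound 2 `CN(C)c1ccc(/C=N/NC(=O)c2cccnc2Nc2cccc(C(F)(F)F)c2)cc1` share the same core and differ only in the group carried on the carbon with a double bond to nitrogen. In a functional assay on the whole organism (strain Wistar) for inhibition, with Rattus norvegicus as the target, read by paw edema, with a stated time of 2 h, at a dose of 10 mg/kg by the intraperitoneal route (on this read-out lower numbers stand for less inhibition and higher numbers for more inhibition at the one dose given (going by the name of the read-out)), compound 1 gives 63.5%, and in this assay compound 2 gives 51.4%. Among the measured compounds shown here, the one step measured so far, a number 12.1 percentage points lower from compound 1 to compound 2 (beyond the scatter), is the only guide to this position. Compound 2 stands lowest of the two numbers in this assay; its nearest neighbour is compound 1, which sits higher by a step beyond the scatter.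

Compound 3 `O=C(N/N=C/c1cccnc1)c1cccnc1Nc1cccc(C(F)(F)F)c1` is the next member: pyridin-3-yl in place of 4-(dimethylamino)phenyl on a carbon with a double bond to nitrogen. For the measured compounds named here, no measured step exchanges a phenyl for pyridin-3-yl on this carbon, so the single step in hand bears on it only loosely. Given that the exchange of aryl groups at this position moved this assay by a modest amount in that step, a step of a number 3.6 percentage points higher from compound 2 to compound 3 (within the scatter) from compound 2 is expected, within the scatter. Compound 3 is therefore estimated at 55% in this assay, with a range from 40% to 70%.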

Compound 3, a percentage reported as inhibition, in the whole organism at one dose (the size of the read-out at that dose, not a potency): 62.4%
Estimate against measurement, compound 3: 7.4 percentage points below; the range from low to high includes it.
By their numbers in this assay, from the lowest: compound 2; then compounds 3 and 1 (each within the scatter of the next).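

At this position, a further exchange of aryl groups gives a number 11 percentage points higher from compound 2 to compound 3 (beyond the scatter) in this assay, so the lower number stands out for 4-(dimethylamino)phenyl against two other aryl groups rather than against one. Pyridin-3-yl and 3-chlorophenyl cannot be told apart on this read-out, at a number 1.1 percentage points lower from compound 1 to compound 3 (within the scatter), so a ring with a hetero atom and a carbon-only ring carrying chlorine give matching results here. No measurement at hand bears on why these groups differ or match.

The compounds shown leave open whether the lower number of compound 2 goes with the dimethylamino group itself or would also appear with another amine on the ring. Also open, going by these compounds, is how a plain phenyl, a carboxylic acid on the ring or a saturated ring would read on this carbon.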